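The source may report more compounds than this note shows. Statements on the series, on what has been measured and on what is new or still open speak of the compounds shown alone.

The pair measured so far are compound 1 `CC(=O)OC[C@H]1O[C@@H](n2cc(CN3C(=O)/C(=C\c4ccc(C)cc4)c4ccccc43)nn2)[C@H](OC(C)=O)[C@@H](OC(C)=O)[C@@H]1OC(C)=O` and compound 2 `CC(=O)OC[C@H]1O[C@@H](n2cc(CN3C(=O)/C(=C/c4cccs4)c4ccccc43)nn2)[C@H](OC(C)=O)[C@@H](OC(C)=O)[C@@H]1OC(C)=O`. In a functional assay on HeLa cells (Homo sapiens) for cytotoxicity, read by sulforhodamine B assay, with a stated time of 48 h (a higher number here means a weaker inhibitor, a lower number a stronger inhibitor), compound 1 reaches only a limit, > 100000 nM, not a number. In this assay, within the data shown here, compound 2 gives 36900 nM, the one plain number recorded, so it sits alone as the only compound with a measured inhibitory concentration, the other entry being (the limit of > 100000 nM in this assay, at which 1 of the 2 values shown sits). Among the measured compounds shown here, compound 1 differs from compound 2 in more than one place, so no single step between measured compounds is available.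

Compound 3 `CC(=O)OC[C@H]1O[C@@H](n2cc(CN3C(=O)/C(=C\c4cccs4)c4ccccc43)nn2)[C@H](OC(C)=O)[C@@H](OC(C)=O)[C@@H]1OC(C)=O` is the next case. Its difference from compound 2 is the two compounds have the same atoms and bonds and differ only in configuration as drawn: 1 of 6 stereo elements differ; a double bond is drawn E in compound 2 and Z in compound 3. For the measured compounds named here, with no measured step of this kind on record, the direction is uncertain; a change that is small or drifts toward weaker inhibition seems most plausible, and a result that ends at the limit cannot be ruled out. The step of a 1.6-fold higher number from compound 2 to compound 3 (0.21 log units; within the scatter) is the expected one. Compound 3 is estimated at 60000 nM, with a range from 20000 nM to 150000 nM.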

Compound 3, half-maximal inhibitory concentration: > 100000 nM
Compound 3: a limit, no number (the forecaster's own chance of this, stated with the estimate: 40%); middle value at least 1.6-fold (0.22 log units) away from the limit.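

In this assay, the series now has its first readable step, and it comes from configuration alone: an at least 2.7-fold higher number from compound 2 to compound 3 (0.43 log units; beyond the scatter). Compound 3 reaches only a limit, > 100000 nM, not a number, so the true size of this step may be larger than the printed one. With thiophen-2-yl kept in place, the drawing of the double bond is therefore enough to separate a measured compound from one at the limit, and the change can be tied to that configuration: the fact that compounds 2 and 3 differ only in the configuration as drawn.

The step from compound 1 to compound 3 cannot be read, since both end at a limit: the limit of > 100000 nM in this assay, at which 2 of the 3 values shown sit. As far as these compounds go, whether 4-methylphenyl and thiophen-2-yl differ at all on this double bond stays open, as does what an amine or a carboxylic acid in that place would give in either configuration.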